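This account rests on a few compounds, and the source may have more. Where it says the series, first, only, none or still open, it means among the compounds named here.

Series notes. Compound 1 `COc1ccc(NC(=O)CN(c2cc(Cl)ccc2OC)S(=O)(=O)c2ccccc2)cc1OC` and compound 2 `COc1cccc(NC(=O)CN(c2cc(Cl)ccc2OC)S(=O)(=O)c2ccccc2)c1` share one core and differ only in a methoxy on an aromatic carbon that compound 2 lacks. In a functional assay on SH-SY5Y cells (Homo sapiens), read by MTT assay, with a stated time of 24 h (on this read-out higher numbers stand for an effect only at larger amounts of compound and lower numbers for an effect already at smaller amounts), compound 1 gives only a limit of the assay, > 20000 nM, not a number. In this assay compound 2 gives 17600 nM. Within the data shown here, compound 2 thus stands as the single compound with a number in this assay; the other value shown is a limit. The step of an at least 1.1-fold lower number from compound 1 to compound 2 (0.05 log units; that floor lies within the scatter) lies within the scatter, and with compound 1 sitting at the limit of > 20000 nM in this assay, at which 1 of the 2 values shown sits, its size cannot be fixed further.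

Compound 3 `COc1ccc(Cl)cc1N(CC(=O)Nc1ccc([N+](=O)[O-])cc1)S(=O)(=O)c1ccccc1` differs from compound 2 in one place: 4-nitrophenyl in place of 3-methoxyphenyl on an amide-type nitrogen. No measured step touches this change; the only step shown, hydrogen in place of methoxy on an aromatic carbon, did not move the number beyond the scatter. Compound 3 is therefore expected in this assay to stay near compound 2, with the step of a 1.0-fold higher number from compound 2 to compound 3 (0.01 log units; within the scatter) expected to lie within the scatter. The estimate for compound 3 is 18000 nM, within 6000 nM to 50000 nM, with a real chance that only a limit is reported.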

Compound 3, half-maximal effective concentration: 8210 nM
For compound 3 the middle estimate is 2.2-fold (0.34 log units) above the measured one; the range from low to high includes it.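

In this assay, among these compounds, the amide-type nitrogen is the first place where a change moves the number beyond the scatter: a 2.1-fold lower number from compound 2 to compound 3 (0.33 log units; beyond the scatter), with 4-nitrophenyl in place of 3-methoxyphenyl. At the same place, 4-nitrophenyl in place of 3,4-dimethoxyphenyl gives an at least 2.4-fold lower number from compound 1 to compound 3 (0.38 log units; beyond the scatter), so the aryl group on this nitrogen does bear on the read-out, though the steps shown are modest in size. Compound 1 gives only a limit of the assay, which makes that second step a floor and not a fixed size: the limit of > 20000 nM in this assay, at which 1 of the 3 values shown sits.

The names 4-nitrophenyl and 3-methoxyphenyl differ both in the group and in its place on the ring, so the compounds shown do not separate the nitro group from where it sits. Nor do they show how a plain phenyl, a 3-nitrophenyl or a 4-aminophenyl on the same amide-type nitrogen would read in this assay, or whether a change elsewhere on the shared core moves the number at all.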